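The compounds below may be only part of what the source reports. "The series", "measured", "known", "first", "only" and "open" are said of these compounds alone.

Among the measured compounds shown here, in a functional assay on HeLa cells (Homo sapiens) for antiproliferative activity, read by MTT assay, with a stated time of 48 h (a lower number here means a stronger inhibitor of growth, a higher number a weaker inhibitor of growth), compound 1 (`COc1cc(/C=C2\Cc3c(cc(OC)c(OC)c3OC)C2=O)cc(OC)c1OC`) gives 2370 nM, the only actual number so far. Compound 2 (`COc1cc2c(c(OC)c1OC)C/C(=C\c1cc(OC)c(OC)c(OC)c1OC)C2=O`) reads > 10000 nM, which is a limit of the assay. Compound 3 (`COc1cc2c(cc1OC)C(=O)/C(=C/c1cc(OC)c(OC)c(OC)c1)C2`) differs from compound 1 by hydrogen in place of methoxy on an aromatic carbon. For the measured compounds named here, the single measured step, an at least 4.2-fold higher number from compound 1 to compound 2 (0.62 log units; beyond the scatter), is methoxy in place of hydrogen at a different aromatic carbon, so it bears only loosely on this change. The expected step, a 1.3-fold lower number from compound 1 to compound 3 (0.12 log units; within the scatter), therefore stays within the scatter, with little confidence in its direction. In this assay the estimate for compound 3 is 1800 nM, with an expected range of 600 nM to 8000 nM.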

Compound 3, concentration for 50% growth inhibition: > 10000 nM
Compound 3: a limit, no number; the forecaster's own chance of this, stated with the estimate: 15%; middle value at least 5.5-fold (0.74 log units) from the limit.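

Methoxy on this aromatic carbon matters in this assay: with hydrogen in its place there is an at least 4.2-fold higher number from compound 1 to compound 3 (0.62 log units; beyond the scatter). Taking away this methoxy thus raises the number, as adding one at a different aromatic carbon did, which leaves compound 1 as the only compound with an actual number. The value of compound 3 is a limit and not a number, so the true size of this step stays unknown: the limit of > 10000 nM in this assay, at which 2 of the 3 values shown sit.

Open, as far as these compounds go, is whether a hydroxyl, an ethoxy or an amine at this position would keep the number of compound 1 or lower it. Also open, from the compounds shown here alone, is how the remaining methoxy groups of the shared core each contribute.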